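From Methoxycarbonyl to Carboxy: An Expected Shift

The compounds below may be only part of what the source reports. "The series", "measured", "known", "first", "only" and "open" are said of these compounds alone.

For the measured compounds named here, in a functional assay on MCF7 cells (Homo sapiens) for cytotoxicity, read by MTT assay (on this read-out higher numbers stand for weaker inhibition and lower numbers for stronger inhibition), compound 2 `COC(=O)C[C@H]1C[C@H](O)[C@@H](C)[C@@H](c2ccc(OC)cc2)N1` gives 5100 nM, the lowest of the three numbers measured so far. Compound 1 `COC(=O)C[C@H]1C[C@@H](O)[C@@H](C)[C@@H](c2ccc(OC)cc2)N1` gives 10400 nM, and compound 3 `COC(=O)C[C@H]1C[C@H](O)[C@@H](C)[C@@H](c2ccc(F)cc2)N1` gives 18200 nM. The first comparison shows a 2.0-fold lower number from compound 1 to compound 2 (0.31 log units; beyond the scatter), and this gap is tied to the fact that compounds 1 and 2 differ only in the configuration as drawn. The second, with fluoro in place of methoxy on an aromatic carbon, shows a 3.6-fold higher number from compound 2 to compound 3 (0.55 log units; beyond the scatter).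

Compound 4 `COc1ccc([C@H]2N[C@@H](CC(=O)O)C[C@H](O)[C@H]2C)cc1` has not yet been measured. Its difference from compound 2 is hydrogen in place of methyl on an oxygen next to a carbonyl group, which turns methoxycarbonyl into carboxy. Neither measured step touches this group, so both serve only as a yardstick of size, and even the larger, a 3.6-fold higher number from compound 2 to compound 3 (0.55 log units; beyond the scatter), was modest. Compound 2 already holds the lowest number at 5100 nM, so a rise looks likelier than a fall. Going by the values given here, the expected change is a 3.9-fold higher number from compound 2 to compound 4 (0.59 log units; beyond the scatter) in this assay, similar in size to the fluoro step but with wide uncertainty, since no direct precedent exists. For compound 4 the estimated value is 20000 nM, with an expected range from 6000 nM to 70000 nM.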

Compound 4, half-maximal inhibitory concentration: 12500 nM
Estimate against measurement, compound 4: 1.6-fold (0.20 log units) above; the measured number falls inside the stated range.
By their numbers in this assay, from the lowest: compound 2; then compounds 1, 4 and 3 (each within the scatter of the next).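

For the compounds shown here, every earlier compound carries methoxycarbonyl, so this is the first reading of a change at that group. In this assay, putting hydrogen in place of methyl on that oxygen gives a 2.5-fold higher number from compound 2 to compound 4 (0.39 log units; beyond the scatter), which is a modest but real rise: the methyl contributes to the lower number of compound 2, yet the carboxy compound still gives a measurable value in the same assay, so the ester is not essential for a reading here. None of the information at hand bears on why this change raises the number.

The compounds shown leave open how other groups would read in place of methoxycarbonyl, such as an ethyl ester, a primary amide or a longer chain ending in a carboxylic acid, so a single step cannot tell whether the methyl itself matters or any ester would serve. From the compounds shown here alone, it also stays open whether the same change would give a step of similar size on the fluoro compound 3, or on compound 1 with its different configuration at the saturated ring carbon.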